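Methyl on the Pyrrole Nitrogen in Rat Paw Edema

The source may hold more compounds than are shown below. What is called first, only, known or untested is meant among the compounds shown, and "the series" means these compounds.

Of the compounds shown here, three of a single series have been tested in a functional assay on the whole organism (strain Wistar Albino) for inhibition, with Rattus norvegicus as the target, read by paw edema, with a stated time of 2 h, at a dose of 20 mg/kg; on this read-out higher numbers stand for more inhibition at the one dose given (going by the name of the read-out) and lower numbers for less inhibition. Compound 1 `COc1ccc(Cl)c(-c2nnc3n2NC(c2ccc[nH]2)S3)c1` gives 15.2% in this assay. Compound 3 `COc1ccc(Cl)c(-c2nnc3n2NC(c2cccn2C)S3)c1` differs from compound 1 by methyl in place of hydrogen on an aromatic nitrogen, and in this assay compound 3 gives 16.8%, so that the change made a number 1.6 percentage points higher from compound 1 to compound 3 (within the scatter). Compound 2 `Cc1occc1-c1nnc2n1NC(c1ccc[nH]1)S2` carries a different core; how the core of compound 2 differs from the core of compound 1 is not broken down here. In this assay compound 2 gives 18.2%, a number that lies within the scatter of the other two, so the three measured compounds cannot be told apart on this read-out.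

Compound 4 `Cc1occc1-c1nnc2n1NC(c1cccn1C)S2` has not yet been measured. It differs from compound 2 by methyl in place of hydrogen on an aromatic nitrogen, the same change that leads from compound 1 to compound 3, made on the other core. Since that change produced only a number 1.6 percentage points higher from compound 1 to compound 3 (within the scatter), a step within the scatter, the account rests on one precedent and on the value of compound 2, which is 18.2%. Compound 4 is therefore expected to show a step of about a number 1.6 percentage points higher from compound 2 to compound 4 (within the scatter), again within the scatter. On that basis compound 4 is estimated to give 19.8% in this assay, with a likely range from 10% to 30%.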

Compound 4, a percentage reported as inhibition, in the whole organism at one dose (the size of the read-out at that dose, not a potency): 18.9%
For compound 4 the middle estimate is 0.9 percentage points above the measured one, within the range that was stated.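

In this assay, the change from 1H-pyrrol-2-yl to 1-methyl-1H-pyrrol-2-yl gives a number 0.7 percentage points higher from compound 2 to compound 4 (within the scatter). Set beside the earlier step, the same change on the two cores gives results that cannot be told apart: the same change on two cores in this assay, a number 1.6 percentage points higher (within the scatter) from compound 1 to compound 3 and a number 0.7 percentage points higher (within the scatter) from compound 2 to compound 4, 0.9 percentage points apart, within the scatter of two such steps This shows that the methyl on the aromatic nitrogen behaves alike on both cores only in the sense that neither step can be distinguished from no change at all, so what carries over is the absence of a measurable step; it does not show that the methyl has any effect on inhibition on either core, and two cores at one dose and one time are too little to support a rule for the whole series.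

The compounds shown carry only hydrogen or methyl on that nitrogen, so it remains open what a longer chain such as ethyl or butyl, or a chain ending in an amine or a carboxylic acid, would do in that place. On these data alone, it also remains open whether any change to this series can produce a step beyond the scatter, and whether the methyl would matter at other doses or times.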